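The compounds below may be only part of what the source reports. "The series", "measured", "known", "first", "only" and "open" are said of these compounds alone.

In a functional assay on Bel7402/5-FU cells (Homo sapiens) for antiproliferative activity, read by MTT assay, with a stated time of 72 h (a lower number here means a stronger inhibitor, a higher number a weaker inhibitor), compound 1 `C=C1C(=O)O[C@H]2[C@H]1CC/C(COC(=O)Cn1cc(F)c(=O)[nH]c1=O)=C\CC[C@@]1(C)O[C@@H]21` reaches no number and stands only at a limit, > 20000 nM. Compound 2 `C=C1C(=O)O[C@H]2[C@H]1CC/C(COC(=O)CCC(=O)OCn1cc(F)c(=O)[nH]c1=O)=C\CC[C@@]1(C)O[C@@H]21` likewise gives only a limit, > 20000 nM. Compound 3 `C=C1C(=O)O[C@H]2[C@H]1CC/C(Cn1cc(Cn3cc(F)c(=O)n(Cc4ccccc4)c3=O)nn1)=C\CC[C@@]1(C)O[C@@H]21`, which carries a benzyl group on an aromatic nitrogen, gives a measured 8840 nM. Compound 4 `C=C1C(=O)O[C@H]2[C@H]1CC/C(COC(=O)Cn1cc(F)c(=O)n(Cc3ccc(Cl)cc3)c1=O)=C\CC[C@@]1(C)O[C@@H]21` departs from compound 1 by 4-chlorobenzyl in place of hydrogen on an aromatic nitrogen. Within the data shown here, no measured step isolates this change, so the expectation rests on compound 3 at 8840 nM: a modest move toward stronger inhibition in this assay, probably beyond the usual scatter. The expected step is an at least 2.2-fold lower number from compound 1 to compound 4 (0.34 log units; beyond the scatter). For compound 4 the estimated value is 9000 nM, with an expected range from 3000 nM to 20000 nM.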

Compound 4, half-maximal inhibitory concentration: 2420 nM
Estimate against measurement, compound 4: 3.7-fold (0.57 log units) above; the whole stated range lies above it.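

Replacing hydrogen with 4-chlorobenzyl on this aromatic nitrogen turns a limit into a measured number in this assay, giving an at least 8.2-fold lower number from compound 1 to compound 4 (0.91 log units; beyond the scatter). Among these compounds, until this result, no step between compounds differing in one place had reached this position. The size of the step is only a floor, since compound 1 stands at a limit: the limit of > 20000 nM in this assay, at which 2 of the 4 values shown sit.

Open, as far as these compounds go, is how a plain benzyl, a methyl or a longer alkyl chain on this nitrogen would compare on the same core. Also open, from the compounds shown here alone, is whether the chlorine on the benzyl ring contributes at all.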